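A Chlorine Shift Repeated on a Second Core

This account rests on a few compounds, and the source may have more. Where it says the series, first, only, none or still open, it means among the compounds named here.

In a functional assay on NCI-H460 cells (Homo sapiens) for inhibition, read by MTT assay, with a stated time of 24 h, tested at 10 ug/mL (a lower number here means less inhibition of growth, a higher number more inhibition of growth at the concentration tested), compound 1 `CC(=O)SCCC(CCCCC(=O)Nc1cccc(Cl)c1)SC(C)=O` gives 2.09%, and compound 2 `CC(=O)SCCC(CCCCC(=O)Nc1ccc(Cl)cc1)SC(C)=O` gives 14.9%. The two differ only in 4-chlorophenyl in place of 3-chlorophenyl on an amide-type nitrogen, and the step of a number 12.8 percentage points higher from compound 1 to compound 2 (beyond the scatter). Compound 3 `O=C(CCCCC(CCSC(=O)c1ccccc1)SC(=O)c1ccccc1)Nc1cccc(Cl)c1` carries another core; the difference between the core of compound 1 and the core of compound 3 is not broken down here. In this assay compound 3 gives 9.12%, a number within the scatter of both compound 1 and compound 2. Compound 4 `O=C(CCCCC(CCSC(=O)c1ccccc1)SC(=O)c1ccccc1)Nc1ccc(Cl)cc1` has not yet been measured. It differs from compound 3 by 4-chlorophenyl in place of 3-chlorophenyl on an amide-type nitrogen, the same change at the same place that separates compound 1 from compound 2. Among the measured compounds shown here, compound 4 is therefore expected to move in the same direction, and the step from compound 3 is estimated as a number 9.9 percentage points higher from compound 3 to compound 4 (within the scatter), resting on the single earlier step of a number 12.8 percentage points higher from compound 1 to compound 2 (beyond the scatter), with wide room: that change has been seen only once and on another core. Compound 4 is expected to give about 19% in this assay, estimated to fall between 5% and 33%.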

Compound 4, percent growth inhibition at one concentration: 12.6%
Estimate against measurement, compound 4: 6.4 percentage points above; low and high end bracket the measured number.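

In this assay, 4-chlorophenyl in place of 3-chlorophenyl on the amide-type nitrogen of the second core gives a number 3.5 percentage points higher from compound 3 to compound 4 (within the scatter), so on this core the change cannot be told from no change at all. Set beside the earlier step, the new one cannot be told apart from it: the same change on two cores in this assay, a number 12.8 percentage points higher (beyond the scatter) from compound 1 to compound 2 and a number 3.5 percentage points higher (within the scatter) from compound 3 to compound 4, 9.3 percentage points apart, within the scatter of two such steps. Among the compounds shown here, this shows that the two results are compatible with the change carrying over from the core of compound 1 to the core of compound 3, but it does not show that it does, as the step lies beyond the scatter on only one core and two pairs establish no rule for the series.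

The compounds shown leave open whether the change would hold on cores with free thiols in place of the thioesters, or with a longer chain between the amide and the sulfur atoms. They also leave open how a fluorine or a methoxy group in place of the chlorine would read in this assay.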